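Three limits and a dibromo swap

The compounds below may be only part of what the source reports. "The series", "measured", "known", "first", "only" and "open" are said of these compounds alone.

Values in a functional assay on ECV-304 cells (Homo sapiens) for cytotoxicity (a higher number here means a weaker inhibitor, a lower number a stronger inhibitor), each one a limit of the assay:
Compound 1 `COc1ccc(S(=O)(=O)NN2C(=S)S/C(=C\c3ccc(Cl)c(Cl)c3)C2O)cc1` gives > 50000 nM as its entry
Compound 2 `O=C1/C(=C/c2ccc(Cl)c(Cl)c2)SC(=S)N1NS(=O)(=O)c1cccs1` gives > 50000 nM as its entry
Compound 3 `O=C1/C(=C/c2ccccc2F)SC(=S)N1NS(=O)(=O)c1ccccc1` gives > 50000 nM as its entry

Compound 3 stands at > 50000 nM in this assay, which is a limit and not a number. Within the data shown here, no measured pair in this set gives a step with a size, so any change has to be estimated.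

Compound 4 `O=C1/C(=C/c2ccc(Br)c(Br)c2)SC(=S)N1NS(=O)(=O)c1ccccc1` has not yet been measured. It differs from compound 3 in one place, and 3,4-dibromophenyl in place of 2-fluorophenyl on a double-bonded chain carbon bound to a double-bonded ring carbon is the count for that change: 3,4-dibromophenyl in place of 2-fluorophenyl on a double-bonded chain carbon bound to a double-bonded ring carbon.

Compound 3 shares its position with compound 1 and compound 2, with the limit of > 50000 nM in this assay, at which 3 of the 3 values shown sit, as the only ground for a forecast. On that ground, no shift beyond the scatter is expected in either direction, and another limit is the likeliest result. The estimated size of the change is a number no higher from compound 3 to compound 4 (the limit leaves the size open) as an expected figure. For compound 4 the expected value is 50000 nM as a middle estimate, with an estimated range from 25000 nM to 100000 nM around it.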

Compound 4, half-maximal inhibitory concentration: > 50000 nM
Compound 4: only a limit was reported; the forecaster's own chance of this, stated with the estimate: 75%; the middle value lies on the limit itself.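

In this assay, among these compounds, compound 4 gives > 50000 nM, which is a limit of the assay, and compound 3 also has only a limit, so no step between these two compounds can be read. What stays open is how strong any compound shown really is, and whether 3,4-dibromophenyl in place of 2-fluorophenyl changes that at all, with one shared mark as the only result: the limit of > 50000 nM in this assay, at which 4 of the 4 values shown sit.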